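Compound 2 to compound 4: piperidin-4-yl replaced by 4-hydroxybutyl

A few compounds are considered here, and "the series" means these few. Any claim that something is new, unique, unknown or untested is made for them only; others in the source may bear on it.

Going by the values given here, in a functional assay on MCF7 cells (Homo sapiens) for inhibition, read by MTT assay, with a stated time of 72 h (a lower number here means a stronger inhibitor, a higher number a weaker inhibitor), compound 2 (`CC(C)=CCC[C@H](C)c1ccc(C)c2c1OCN(CC1CCNCC1)C2`) gives 8100 nM as the only true number in the set. Compound 1 (`CC(C)=CCC[C@H](C)c1ccc(C)c(CNCCO)c1O`) gives > 20000 nM as a limit. Compound 3 (`CC(C)=CCC[C@H](C)c1ccc(C)c(CNCC2CCNCC2)c1O`) gives > 20000 nM as a limit too. The series therefore rests largely on the limit of > 20000 nM in this assay, at which 2 of the 3 values shown sit, and offers little to calibrate against.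

Compound 4 (`CC(C)=CCC[C@H](C)c1ccc(C)c2c1OCN(CCCCCO)C2`) keeps the shared core and differs from compound 2 by 4-hydroxybutyl in place of piperidin-4-yl on a saturated chain carbon bound to an amine nitrogen in a ring in the side chain, which reads in full as (piperidin-4-yl)methyl to 5-hydroxypentyl.

Among the compounds with values here, the only measured step involving a similar exchange is a step that the two limits leave unreadable from compound 1 to compound 3 and it has no readable size, so it sets no direction. No shift beyond the scatter is therefore expected in this assay. The estimate is a 1.2-fold higher number from compound 2 to compound 4 (0.09 log units; within the scatter) and this expected step stays small. For compound 4 the expected value is 10000 nM with an estimated range from 4000 nM to 20000 nM and with some chance of a limit reading.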

Compound 4, half-maximal inhibitory concentration: 6900 nM
Beside the measured number, compound 4's estimate is 1.4-fold (0.16 log units) above it; measured number inside the range.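

In this assay, exchanging piperidin-4-yl for 4-hydroxybutyl on a saturated chain carbon bound to an amine nitrogen in a ring gives a 1.2-fold lower number from compound 2 to compound 4 (0.07 log units; within the scatter). This position therefore takes an open chain in place of the six-membered non-aromatic ring with no shift beyond the scatter, and the ring is not needed to keep a true number in this assay. Going by these compounds alone, the one earlier step of a similar kind cannot be read, as both of its ends are limits, so this is the only size available for a change of this sort.

Going by these compounds, whether a carboxylic acid, a primary amine or a shorter chain in place of 4-hydroxybutyl would move the number beyond the scatter stays open. The series also remains thinly anchored: the limit of > 20000 nM in this assay, at which 2 of the 4 values shown sit.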